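This account rests on a few compounds, and the source may have more. Where it says the series, first, only, none or still open, it means among the compounds named here.

Working notes on the series. Compound 1 `COc1ccccc1CN(C)Cc1ccc(/C=C2\COc3cc(OC)c(OC)cc3C2=O)cc1O`, compound 2 `CCN(Cc1ccccc1)Cc1ccc(/C=C2\COc3cc(OC)c(OC)cc3C2=O)cc1O` and compound 3 `COc1ccccc1CN(C)Cc1c(O)cccc1/C=C1\COc2cc(OC)c(OC)cc2C1=O` have been measured; compound 4 `CCN(Cc1ccccc1)Cc1c(O)cccc1/C=C1\COc2cc(OC)c(OC)cc2C1=O` has not. In an assay on isolated protein for inhibition of Amine oxidase [flavin-containing] A (Homo sapiens), read by fluorescence, with a stated time of 30 min, tested at 20 uM (on this read-out higher numbers stand for more inhibition at the one concentration tested (going by the name of the read-out) and lower numbers for less inhibition), compound 1 gives 12.3%. In this assay compound 2 gives 15%. In this assay compound 3 gives 9.8%. Compound 3 stands lowest of the three numbers, but its gaps to compound 1 and to compound 2 both lie within the scatter, so no order among the three is claimed.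

One structural change occurs twice in the set: benzyl(ethyl)amino in place of (2-methoxybenzyl)(methyl)amino on a saturated chain carbon bound to an aromatic carbon. Between the measured pair it made a number 2.7 percentage points higher from compound 1 to compound 2 (within the scatter). Compound 3 and compound 4 differ by the same change, (benzyl(ethyl)amino in place of (2-methoxybenzyl)(methyl)amino on a saturated chain carbon bound to an aromatic carbon), and the two place descriptions agree word for word, so it is the same change carried onto a different core. How the core of compound 3 differs from the core of compound 1 is not broken down here; the two share the same atoms, joined differently.

The expectation for compound 4 rests on a single precedent. Because the step of a number 2.7 percentage points higher from compound 1 to compound 2 (within the scatter) was within the scatter, a step of like size is expected, a number 2.2 percentage points higher from compound 3 to compound 4 (within the scatter). Compound 4 is therefore expected to give about 12% in this assay, with an expected range from 4% to 22%. A numerical reading at the single concentration is expected rather than a limit.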

Compound 4, a percentage reported as inhibition, at one concentration (the size of the read-out at that concentration, not a potency): 9.8%
Estimate against measurement, compound 4: 2.2 percentage points above, and the stated range covers the measured number.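

In this assay, benzyl(ethyl)amino in place of (2-methoxybenzyl)(methyl)amino gives no change at the digits printed from compound 3 to compound 4 (within the scatter), and setting this step beside the earlier one does not separate the two cores: the same change on two cores in this assay, a number 2.7 percentage points higher (within the scatter) from compound 1 to compound 2 and no change at the digits printed (within the scatter) from compound 3 to compound 4, 2.7 percentage points apart, within the scatter of two such steps. The change therefore behaves alike on the core of compound 1 and the core of compound 3 in the limited sense that neither step lies beyond the scatter. Going by these compounds alone, this does not show that the change is without effect in general or that the two steps are truly equal, and with only two steps, neither of them beyond the scatter, the series offers no clear effect whose transfer from one core to the other could be tested.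

The compounds shown carry only these two amine groups on the saturated chain carbon, so it remains open how dimethylamino, an amine with a longer chain on the nitrogen such as dibutylamino, or a carboxylic acid in the same place would read on either core. Also open, as far as these compounds go, is whether any such group would move the reading in this assay beyond the scatter, and whether a step of that size would then carry from one core to the other.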